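The source may report more compounds than this note shows. Statements on the series, on what has been measured and on what is new or still open speak of the compounds shown alone.

Series notes, aryl group on the five-membered ring.

Compound 1 `O=C(NO)c1ccc(NCc2nc(-c3ccco3)nn2-c2ccccc2)cc1` and compound 2 `O=C(NO)c1ccc(NCc2nc(-c3cccnc3)nn2-c2ccccc2)cc1` share the whole hydroxamic acid scaffold and differ only in the aryl group. In an assay on Sf9 cells for inhibition of protein deacetylase HDAC6 (Homo sapiens), read by fluorescence, with a stated time of 40 min, tested at 100 nM (on this read-out lower numbers stand for less inhibition and higher numbers for more inhibition at the one concentration tested (going by the name of the read-out)), compound 1 gives 59.9% and compound 2 gives 57.7%. Among the measured compounds shown here, the only step so far is a number 2.2 percentage points lower from compound 1 to compound 2 (within the scatter), so compound 2 stands together with compound 1 and the two numbers cannot be told apart.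

The next compound is compound 3 `O=C(NO)c1ccc(NCc2nc(-c3ccc(F)cc3)nn2-c2ccccc2)cc1`, in which (4-fluorophenyl in place of pyridin-3-yl on an aromatic carbon). For the measured compounds named here, the one measured step that bears on an aryl swap at this carbon is a number 2.2 percentage points lower from compound 1 to compound 2 (within the scatter), which stayed within the scatter when a six-membered ring with one nitrogen replaced a five-membered ring with one oxygen. Going by the values given here, nothing measured separates a pyridin-3-yl from a 4-fluorophenyl here, and the one comparison available shows the aryl group moving the read-out little. For compound 3 the expected step is therefore a number 0.3 percentage points higher from compound 2 to compound 3 (within the scatter), no direction beyond the scatter. Compound 3 is estimated at 58% in this assay, with a range from 45% to 70%.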

Compound 3, a percentage reported as inhibition, at one concentration (the size of the read-out at that concentration, not a potency): 70.9%
Beside the measured number, compound 3's estimate is 12.9 percentage points below it; measured number above the stated range.
By their numbers in this assay, from the lowest: compounds 2 and 1 (each within the scatter of the next); then compound 3.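

Among the compounds shown here, the aryl group at this carbon, between two ring nitrogen atoms, can move the read-out in this assay after all: 4-fluorophenyl gives a number 13.2 percentage points higher from compound 2 to compound 3 (beyond the scatter) and also a number 11 percentage points higher from compound 1 to compound 3 (beyond the scatter), whereas the only earlier swap, between two rings that each hold a hetero atom, stayed within the scatter. Among these three compounds, the ring of carbon only stands apart from the furan-2-yl and the pyridin-3-yl, which remain together, but both steps bring in a ring of carbon only and a fluorine at once, so the numbers cannot assign the gain to either feature. No supporting data bear on why the 4-fluorophenyl compound reads higher.

As far as these compounds go, what stays open is whether the fluorine matters at all, since an unsubstituted phenyl at this carbon would separate it from the ring change, and a 4-chlorophenyl or 4-methoxyphenyl would show whether other groups at that ring position behave alike. Also open, from the compounds shown here alone, is whether the step holds as a difference in potency, as each number here is a reading at one concentration.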